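Alkoxy shortening in the nitro-dihydropyridine ester series

The compounds below may be only part of what the source reports. "The series", "measured", "known", "first", "only" and "open" are said of these compounds alone.

Three compounds carry numbers in a functional assay (cardiac atrium) for agonist activity, with Cavia porcellus as the target; a lower number here means that less compound is needed, a higher number that more compound is needed for the effect. Compound 1 `CC1=NC(C)=C([N+](=O)[O-])C(c2cccnc2)/C1=C(\O)OC1CCCCC1` gives 2760 nM, compound 2 `CCO/C(O)=C1\C(C)=NC(C)=C([N+](=O)[O-])C1c1ccccn1` gives 22800 nM, and compound 3 `CC1=NC(C)=C([N+](=O)[O-])C(c2cccnc2)/C1=C(\O)OCC(C)C` gives 1740 nM. Compound 3 stands at the low end of these three numbers; its nearest neighbour is compound 1, within the scatter, while compound 2 lies far above it, beyond the scatter. Within the data shown here, the one measured step that shares the varied position is a 1.6-fold lower number from compound 1 to compound 3 (0.20 log units; within the scatter), which shows that a sizeable change of the alkoxy group left this assay essentially unmoved.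

Compound 4 `CCO/C(O)=C1\C(C)=NC(C)=C([N+](=O)[O-])C1c1cccnc1` is the next step from compound 3: methyl in place of isopropyl on a saturated chain carbon bound to an oxygen on an unsaturated carbon. Among the measured compounds shown here, compound 2 also bears the ethoxy group of compound 4, but it differs from compound 4 elsewhere in the structure, so its high number cannot be charged to the alkoxy group alone; what its value and that of compound 3 show is only that two compounds with different alkoxy groups and different attachment of the aromatic ring lie well apart. Given the flat step from compound 1 to compound 3, the expected step of a 1.8-fold higher number from compound 3 to compound 4 (0.26 log units; within the scatter) is small, with some risk of a weaker result if the larger groups were favoured. Compound 4 is estimated at 3200 nM, in the range 1100 nM to 9500 nM.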

Compound 4, half-maximal effective concentration: 8840 nM
Estimate against measurement, compound 4: 2.8-fold (0.44 log units) below; the measured number falls inside the stated range.
By their numbers in this assay, from the lowest: compounds 3 and 1 (each within the scatter of the next); then compound 4; then compound 2.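

Unlike the flat exchange of cyclohexyl for isobutyl, the shortening to ethoxy registers in this assay: methyl in place of isopropyl on a saturated chain carbon bound to an oxygen on an unsaturated carbon gives a 5.1-fold higher number from compound 3 to compound 4 (0.71 log units; beyond the scatter) and ethyl in place of cyclohexyl gives a 3.2-fold higher number from compound 1 to compound 4 (0.51 log units; beyond the scatter), so this position responds once the group on the oxygen is cut back to ethyl, although the size of that response is modest. With the ethoxy group held constant, compound 4 also isolates the attachment of the aromatic ring, and pyridin-3-yl in place of pyridin-2-yl on a saturated ring carbon gives a 2.6-fold lower number from compound 2 to compound 4 (0.41 log units; beyond the scatter), which means that the high number of compound 2 cannot be read as an effect of the ethoxy group alone. Nothing available here accounts for either step.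

Open, as far as these compounds go, is whether methoxy continues the rise seen on going to ethoxy and whether a straight n-butyl chain stays with isobutyl and cyclohexyl or moves towards ethyl. Also open, from the compounds shown here alone, is how pyridin-4-yl or phenyl would compare on the saturated ring carbon, and whether the pyridin-2-yl to pyridin-3-yl step carries over to an isobutoxy compound.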